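The source may hold more compounds than are shown below. What is called first, only, known or untested is meant among the compounds shown, and "the series" means these compounds.

Measured in an ADME assay on L02 cells (Homo sapiens) for cytotoxicity, read by MTT assay, with a stated time of 24 h; on this read-out lower numbers stand for stronger inhibition and higher numbers for weaker inhibition:
- compound 1 `COc1ccc(/C=C2\CN(C)C/C(=C\c3ccccc3F)C2=O)cc1OC`: 10500 nM
- compound 2 `COc1cc(/C=C2\CN(C)C/C(=C\c3cccc([N+](=O)[O-])c3)C2=O)cc(OC)c1`: 10800 nM
- compound 3 `COc1cc(/C=C2\CN(C)C/C(=C\c3cc(OC)c(OC)c(OC)c3)C2=O)cc(OC)c1`: 14600 nM

Compound 3 lies within the usual scatter of both compound 1 and compound 2, so these numbers set no order among the three. Compound 4 `COc1cc(/C=C2\CN(C)C/C(=C\c3ccc(C#N)cc3)C2=O)cc(OC)c1OC` has 4-cyanophenyl in place of 3,5-dimethoxyphenyl on a double-bonded chain carbon bound to a double-bonded ring carbon. Among the compounds with values here, no two measured compounds differ in only one place, so no direct guide exists for this change. Still, compound 1 at 10500 nM and compound 3 at 14600 nM carry different groups yet stay within the scatter, so no step beyond the scatter is expected in this assay. The expected step, a 1.3-fold lower number from compound 3 to compound 4 (0.12 log units; within the scatter), is small. Compound 4 is estimated at 11000 nM, with an expected range from 5000 nM to 22000 nM.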

Compound 4, half-maximal inhibitory concentration: 18600 nM
Compound 4: middle estimate off by 1.7-fold (0.23 log units), on the low side; the range from low to high includes it.
By their numbers in this assay, from the lowest: compounds 1, 2, 3 and 4 (each within the scatter of the next).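

In this assay, exchanging one group on the shared core gives a 1.3-fold higher number from compound 3 to compound 4 (0.11 log units; within the scatter). Within the data shown here, this is the only pair here that differs in one place, so it offers the first direct reading at this position: this exchange of groups does not move the number beyond the scatter. No measured information explains this result.

As far as these compounds go, whether a phenyl group carrying an amine or a carboxylic acid would behave the same way at this position remains open. So does whether this exchange would give a similar step on a different core.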